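Halogen swap on the amine-linked phenyl: cytotoxicity notes

This account rests on a few compounds, and the source may have more. Where it says the series, first, only, none or still open, it means among the compounds named here.

The series shares the core seen in compound 2 `O=c1cc(CNCc2ccccc2I)oc2ccc(O)c(O)c12`. In an ADME assay on Huh-7 cells (Homo sapiens) for cytotoxicity (a lower number here means that less compound is tolerated, a higher number that more compound is tolerated), compound 2 gives 87300 nM. Compound 1 `O=c1cc(CNCc2ccccc2Cl)oc2ccc(O)c(O)c12` carries chloro where compound 2 carries iodo. In this assay compound 1 reaches only a limit of the assay, > 100000 nM, and no number. Across this pair the recorded step is an at least 1.1-fold lower number from compound 1 to compound 2 (0.05 log units; that floor lies within the scatter). Among the compounds with values here, compound 2 therefore stands as the only actual number in this assay. The other entry, for compound 1, is the limit of > 100000 nM in this assay, at which 1 of the 2 values shown sits.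

Compound 3 `O=c1cc(CNCc2cccc(Br)c2)oc2ccc(O)c(O)c12` differs from compound 2 by 3-bromophenyl in place of 2-iodophenyl on a saturated chain carbon bound to an amine nitrogen. Within the data shown here, the only measured step that touches the halogen on that ring is the one from compound 1 to compound 2, and it stayed within the scatter. Among the measured compounds shown here, no measured pair moves from a 2-iodophenyl to a 3-bromophenyl group, so that part of the change has no direct precedent here. The expectation for this assay is thus a step of no clear size beyond the scatter, in neither direction. Compound 3 is expected to give 90000 nM, with a range from 40000 nM to 200000 nM. That estimate corresponds to an expected step of a 1.0-fold higher number from compound 2 to compound 3 (0.01 log units; within the scatter).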

Compound 3, half-maximal cytotoxic concentration: > 100000 nM
Compound 3: a limit, no number (the forecaster's own chance of this, stated with the estimate: 40%); at least 1.1-fold (0.04 log units) between middle value and limit.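

In this assay compound 3 gives > 100000 nM, which is a limit of the assay and not a number. Swapping the 2-iodophenyl group for a 3-bromophenyl group gives an at least 1.1-fold higher number from compound 2 to compound 3 (0.05 log units; that floor lies within the scatter); this step changes both the halogen and its place on the ring, yet its floor, like that of the earlier halogen swap, does not clear the scatter, and the true size of the step remains unknown. The step from compound 1 to compound 3 cannot be read, and the series now rests mostly on a single assay boundary: the limit of > 100000 nM in this assay, at which 2 of the 3 values shown sit.

No pair shown moves a halogen around the ring while keeping the halogen the same, so the contributions of halogen identity and ring placement to these readings stay unseparated, and compound 2 remains the only one with an actual number. Also open, as far as these compounds go, is how this assay responds to a methoxy group or a carboxylic acid in place of the halogen, or to a longer chain on the amine nitrogen.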